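Removing the Benzyl Group from Compound 1

The source may report more compounds than this note shows. Statements on the series, on what has been measured and on what is new or still open speak of the compounds shown alone.

This piece follows a single change made to compound 1 `OC[C@H]1O[C@@H](n2cnc3c(NCc4ccccc4)nccc32)C[C@@H]1O`, whose activity was measured in a functional assay (Homo sapiens) for inhibition of Nucleic Acid, tested at 100 uM; a higher number here means more inhibition at the concentration tested (going by the name of the read-out), a lower number less inhibition. In this assay compound 1 gives 15%, the highest of the three numbers recorded. The nearest of the others is compound 3 `OCCNc1[nH]ccc2ncnc1-2`, which in this assay gives 3%, a number lower than that of compound 1 by more than the usual scatter. Furthest away is compound 2 `[O-][n+]1ccc2c(c1)ncn2[C@H]1C[C@H](O)[C@@H](CO)O1`, which in this assay gives 0%, also lower than compound 1 by more than the scatter. Within the data shown here, none of the three measured compounds differs from another in only one place, so no single step between measured compounds can be read off.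

The compound still to be measured is compound 4 `Nc1nccc2c1ncn2[C@H]1C[C@H](O)[C@@H](CO)O1`. It differs from compound 1 in one place: hydrogen in place of benzyl on a nitrogen on an aromatic ring. Cut one bond further out, the difference reads benzylamino to amino.

The expectation rests on compound 2 at 0% and compound 3 at 3%, neither of which carries a benzyl group and both of which sit low in this assay. With the benzyl gone, compound 4 is expected to fall back toward those low numbers, a downward step estimated at a number 10 percentage points lower from compound 1 to compound 4 (within the scatter), which may still lie within the scatter. The estimate for compound 4 is 5%, with a range from 0% to 15%.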

Compound 4, a percentage reported as inhibition, at one concentration (the size of the read-out at that concentration, not a potency): 18%
Compound 4: the middle estimate sits 13 percentage points below what was measured; the whole stated range lies below it.
By their numbers in this assay, from the lowest: compounds 2 and 3 (each within the scatter of the next); then compounds 1 and 4 (each within the scatter of the next).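

In this assay the swap of hydrogen for benzyl on a nitrogen on an aromatic ring gives a number 3 percentage points higher from compound 1 to compound 4 (within the scatter) and so leaves the two compounds indistinguishable in this measurement. Among these compounds, this is the first direct reading of this position, since the earlier compounds differ from one another in more than one place: the whole benzyl group, with its seven carbons and its aromatic ring, can be exchanged for a single hydrogen without a change that stands clear of the scatter, at the one concentration tested. Nothing measured here bears on why the exchange leaves the reading where it is.

The compounds shown give only these two end points at this nitrogen, so it remains open whether a small group such as methyl, a longer chain such as butyl, or an acetyl group would read the same as benzyl and hydrogen or would separate from them. From the compounds shown here alone, both readings are also single-concentration percentages rather than potencies, so it remains open whether compound 1 and compound 4 would stay indistinguishable across a range of concentrations.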